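The source may hold more compounds than are shown below. What is called first, only, known or untested is meant among the compounds shown, and "the series" means these compounds.

Values in an ADME assay on L6 cells (Rattus norvegicus) for cytotoxicity, read by fluorescence and resazurin assay, with a stated time of 72 h; on this read-out higher numbers stand for lower toxicity in this test and lower numbers for higher toxicity in this test:
- compound 1 `N#Cc1ccc(-c2c[nH]cc2C(c2ccc(Cl)cc2Cl)n2ccnc2)cc1`: 15000 nM
- compound 2 `Clc1ccc(C(c2c[nH]cc2-c2ccc(-c3ccncc3)cc2)n2ccnc2)c(Cl)c1`: 15500 nM
- compound 3 `c1ccc(C(c2ccn(-c3ccccc3)c2)n2ccnc2)cc1`: 80800 nM

Compound 3 gives the highest of the three numbers, and compound 1 and compound 2 both lie below it, beyond the scatter. Compound 4 `Fc1ccc(-n2ccc(C(c3ccccc3)n3ccnc3)c2)cc1` has fluoro in place of hydrogen on an aromatic carbon, para to a large group: fluoro in place of hydrogen on an aromatic carbon. Among the compounds with values here, the only measured step, a 1.0-fold higher number from compound 1 to compound 2 (0.01 log units; within the scatter), involves a different exchange at a different place and offers only weak guidance. Within the data shown here, with no measured fluoro step, no shift beyond the scatter is expected in this assay. The estimated step is a 1.2-fold lower number from compound 3 to compound 4 (0.06 log units; within the scatter). Compound 4 is expected at 70000 nM, with an estimated range from 35000 nM to 130000 nM.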

Compound 4, half-maximal cytotoxic concentration: 104000 nM
Beside the measured number, compound 4's estimate is 1.5-fold (0.17 log units) below it; measured number inside the range.
By their numbers in this assay, from the lowest: compounds 1 and 2 (each within the scatter of the next); then compounds 3 and 4 (each within the scatter of the next).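

In this assay, within the data shown here, fluoro in place of hydrogen on the six-membered aromatic ring of carbon only, para to a large group, gives a 1.3-fold higher number from compound 3 to compound 4 (0.11 log units; within the scatter), the first measured step at this position. Phenyl to 4-fluorophenyl therefore leaves the read-out unchanged within the scatter, so this position tolerates a single fluoro in this test. Nothing available bears on the reason for this result.

On these data alone, whether chloro or a larger group such as an amine, a carboxylic acid or a longer chain at this place would also stay within the scatter of compound 3 remains open.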